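The source may hold more compounds than are shown below. What is called first, only, known or untested is meant among the compounds shown, and "the series" means these compounds.

Compound 3 `COc1cc2c(Oc3ccc(NC(=O)c4cc(-c5ccc(Cl)c(Cl)c5)nc5ccccc45)cc3F)ccnc2cc1OCCCN1CCCCC1` is the weakest of the three compounds tested in a functional assay on MKN-45 cells (Homo sapiens) for cytotoxicity, read by MTT assay, with a stated time of 72 h (on this read-out lower numbers stand for stronger inhibition and higher numbers for weaker inhibition), where compound 3 gives 730 nM. Compound 1 `COc1cc2c(Oc3ccc(NC(=O)c4cc(-c5ccc(F)cc5)nc5ccccc45)cc3F)ccnc2cc1OCCCN1CCCCC1` gives 28 nM and compound 2 `COc1cc2c(Oc3ccc(NC(=O)c4cc(-c5cccc(Cl)c5)nc5ccccc45)cc3F)ccnc2cc1OCCCN1CCCCC1` gives 11 nM. The steps of a 26-fold higher number from compound 1 to compound 3 (1.42 log units; beyond the scatter) and a 66-fold higher number from compound 2 to compound 3 (1.82 log units; beyond the scatter) are both large and well beyond the scatter. Compound 4 `COc1cc2c(Oc3ccc(NC(=O)c4cc(-c5ccc(Cl)c(Cl)c5)nc5ccccc45)cc3F)ccnc2cc1OCCCN1CCCC1` keeps everything of compound 3 except one change: pyrrolidin-1-yl in place of piperidin-1-yl on a saturated chain carbon, three bonds along the chain from an oxygen on an aromatic ring. For the measured compounds named here, none of the measured steps touches this part of the molecule, since all three alter only the substituted phenyl ring on the shared core, so no measured step bears directly on this change. With no guidance, the step expected here is small. Compound 4 is estimated at 730 nM, with a range from 300 nM to 1800 nM. The expected no change at the digits printed from compound 3 to compound 4 (within the scatter) therefore stays within the scatter.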

Compound 4, half-maximal inhibitory concentration: 170 nM
For compound 4 the middle estimate is 4.3-fold (0.63 log units) above the measured one, and the stated range ends above it.
By their numbers in this assay, from the lowest: compound 2; then compound 1; then compound 4; then compound 3.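

For the compounds shown here, replacing piperidin-1-yl with pyrrolidin-1-yl at the end of the chain gives a 4.3-fold lower number from compound 3 to compound 4 (0.63 log units; beyond the scatter) in this assay and so shows that this chain end, untouched by the earlier steps, also moves the number. A six-membered ring and a five-membered ring are therefore not interchangeable here, at least with the 3,4-dichlorophenyl group in place. Nothing shown explains why the five-membered ring gives the lower number.

From the compounds shown here alone, whether the same swap would move compound 1 or compound 2, which carry other phenyl groups, remains open. So does the effect of morpholin-4-yl or dimethylamino at this chain end.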